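From Methyl to Amino at a Measuring Limit

This account rests on a few compounds, and the source may have more. Where it says the series, first, only, none or still open, it means among the compounds named here.

Of the compounds shown here, three have been measured so far in a physicochemical assay for solubility, read by chemiluminescence, measured as kinetic solubility; a higher number here means a more soluble compound, a lower number a less soluble compound. Compound 1 `Cn1ncc2c(NS(=O)(=O)c3cccc(Cl)c3Cl)cccc21` gives 170000 nM as a plain number. Compound 2 `Cn1ncc2c(NS(=O)(=O)c3cccc(Cl)c3Cl)ccnc21` gives >= 310000 nM which is a limit of the assay and not a number. Compound 3 `COc1nn(C)c2nc(C)nc(NS(=O)(=O)c3cccc(Cl)c3Cl)c12` gives >= 557000 nM which is likewise only a limit. Its true number is therefore unknown, and it is one of two such limits among the three values.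

Compound 4 `COc1nn(C)c2nc(N)nc(NS(=O)(=O)c3cccc(Cl)c3Cl)c12` differs from compound 3 in one place: amino in place of methyl on an aromatic carbon, between two ring nitrogen atoms (amino in place of methyl on an aromatic carbon). Among the compounds with values here, no measured pair shows this swap, so nothing here gives its size directly. Starting from compound 3 and its limit of >= 557000 nM no step beyond the usual scatter is expected in this assay. The estimated change is an at least 1.2-fold lower number from compound 3 to compound 4 (0.09 log units; that floor lies within the scatter) in size and stays within that scatter. For compound 4 the estimate is 450000 nM with an expected range from 200000 nM to 800000 nM and a limit instead of a number is quite possible.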

Compound 4, solubility: >= 649000 nM
Compound 4: only a limit was reported (the forecaster's own chance of this, stated with the estimate: 55%); middle value at least 1.4-fold (0.15 log units) from the limit.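

Compound 3 and compound 4 each give only a limit of the assay and not a number, and the step between them cannot be read. The compounds shown leave open the true solubility of both and whether amino in place of methyl shifts it at all.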